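A few compounds are considered here, and "the series" means these few. Any claim that something is new, unique, unknown or untested is made for them only; others in the source may bear on it.

Compound 3 `O=[N+]([O-])c1ccc(N2CCN(Cn3nc(-c4ccc5c(c4)OCCO5)oc3=S)CC2)cc1` stands at the edge of what can be measured in a functional assay on BGC-823 cells (Homo sapiens) for antiproliferative activity, read by MTT assay, with a stated time of 48 h; a higher number here means a weaker inhibitor, a lower number a stronger inhibitor. In this assay compound 3 gives > 50000 nM, which is a limit and not a number. Compound 1 `S=c1oc(-c2ccc3c(c2)OCCO3)nn1CN1CCN(c2ccc(Cl)cc2)CC1` likewise reaches that limit, giving > 50000 nM. Compound 2 `S=c1oc(-c2ccc3c(c2)OCCO3)nn1CN1CCN(c2ccccn2)CC1` gives 25900 nM. Two of the three values sit at the limit of > 50000 nM in this assay, at which 2 of the 3 values shown sit. The step of an at least 1.9-fold lower number from compound 1 to compound 2 (0.28 log units; that floor lies within the scatter) has a floor within the scatter, as does an at least 1.9-fold higher number from compound 2 to compound 3 (0.28 log units; that floor lies within the scatter), while a step that the two limits leave unreadable from compound 1 to compound 3 cannot be read. Compound 4 `S=c1oc(-c2ccc3c(c2)OCCO3)nn1CN1CCN(c2cccc(Cl)c2)CC1` differs from compound 3 by 3-chlorophenyl in place of 4-nitrophenyl on an amine nitrogen in a ring. Within the data shown here, no measured step covers this exchange; compound 1, which carries 4-chlorophenyl, sits at the limit. Compound 4 is therefore expected to give 50000 nM, within a range from 20000 nM to 120000 nM, most plausibly again a limit. The step of a number no higher from compound 3 to compound 4 (the limit leaves the size open) is estimated to stay within the scatter.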

Compound 4, half-maximal inhibitory concentration: > 50000 nM
Compound 4 ended at the assay's limit; the forecaster's own chance of this, stated with the estimate: 60%; the middle value sits exactly at the limit.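

In this assay compound 4 gives > 50000 nM, which is a limit and not a number. A chlorine on the phenyl group in the 3-chlorophenyl form therefore reaches the same limit as 4-chlorophenyl and 4-nitrophenyl on this amine nitrogen in a ring, and the steps among these three compounds cannot be read: the limit of > 50000 nM in this assay, at which 3 of the 4 values shown sit. The one readable step is an at least 1.9-fold higher number from compound 2 to compound 4 (0.28 log units; that floor lies within the scatter).

Going by these compounds, how far apart the three substituted phenyl groups truly lie remains open. So does what a benzyl group or a pyrimidin-2-yl ring would give at this nitrogen.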